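The source may report more compounds than this note shows. Statements on the series, on what has been measured and on what is new or still open speak of the compounds shown alone.

Measured so far in a functional assay on SK-BR-3 cells (Homo sapiens) for cytotoxicity, read by resazurin assay, with a stated time of 72 h; a lower number here means a stronger inhibitor, a higher number a weaker inhibitor:
compound 1 `S=C(NCc1cccnc1)SCCc1nc2ccccc2o1` gives 820 nM
compound 2 `S=C(NCc1cccnc1)SCCc1noc(-c2ccccc2)n1` gives 1290 nM
compound 3 `S=C(NCc1cccnc1)SCCc1nnc(-c2ccc(Cl)cc2)o1` gives 860 nM

Compound 3 at 860 nM lies within the usual scatter of both compound 1 and compound 2, so these three values cannot be ranked. For the measured compounds named here, no two of the measured compounds differ in only one place, so no measured step isolates a single change.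

The next compound is compound 4 `S=C(NCc1cccnc1)SCCc1nnc(-c2cccs2)o1`, in which thiophen-2-yl stands in place of 4-chlorophenyl on an aromatic carbon of a five-membered aromatic ring with 2 nitrogen and 1 oxygen (thiophen-2-yl in place of 4-chlorophenyl on an aromatic carbon). Nothing measured shows this exchange directly. Going by the values given here, the only guide is how close the values stay across different structures: compound 1 at 820 nM and compound 2 at 1290 nM both fall within the scatter of compound 3.

On that basis, the expected step of a 1.0-fold higher number from compound 3 to compound 4 (0.02 log units; within the scatter) in this assay stays within the scatter, with no direction expected. With so little to go on, the expected range is kept wide. For compound 4 the estimate is 900 nM with an expected range from 400 nM to 2000 nM in this series.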

Compound 4, half-maximal inhibitory concentration: 1070 nM
For compound 4 the middle estimate is 1.2-fold (0.08 log units) below the measured one; low and high end bracket the measured number.
By their numbers in this assay, from the lowest: compounds 1, 3, 4 and 2 (each within the scatter of the next).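

In this assay, for the compounds shown here, the exchange of 4-chlorophenyl for thiophen-2-yl on the aromatic carbon of the five-membered ring with 2 nitrogen and 1 oxygen gives a 1.2-fold higher number from compound 3 to compound 4 (0.09 log units; within the scatter), which lies within the scatter and is the first measured step that isolates a single change. At this one position, then, a one-ring aryl group of carbon only bearing chlorine and a five-membered aromatic ring with 1 hetero atom cannot be told apart by this read-out, even though the entering group has fewer heavy atoms and adds a hydrogen-bond acceptor by the count. No measured evidence bears on why the two groups read alike, and this single pair sets no rule for other groups at this position.

From the compounds shown here alone, whether the same position keeps such values when it carries a saturated amine such as morpholine, or a carboxylic acid on the phenyl ring, remains open. Also open is how the series responds to changes elsewhere, such as a longer chain in place of the link between the sulfur and the ring, for which the compounds shown offer no single-place comparison.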